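The source may hold more compounds than are shown below. What is called first, only, known or untested is meant among the compounds shown, and "the series" means these compounds.

Compound 1 `CN(C)CCNc1nc(-c2ccc(NC(=O)Nc3ccccc3F)cc2)nc2ccsc12` is the reference point of this short series. In a functional assay on HT-29 cells (Homo sapiens) for cytotoxicity, read by MTT assay, with a stated time of 72 h (on this read-out higher numbers stand for weaker inhibition and lower numbers for stronger inhibition), compound 1 gives 510 nM, the lowest of the two numbers recorded so far. For the measured compounds named here, its closest measured neighbour is compound 2 `Cc1ccc(NC(=O)Nc2ccc(-c3nc(NCCN(C)C)c4sccc4n3)cc2)cc1`, which in this assay gives 2150 nM; the only step measured in this set, a 4.2-fold higher number from compound 1 to compound 2 (0.62 log units; beyond the scatter), arises from placing 4-methylphenyl in place of 2-fluorophenyl on an amide-type nitrogen.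

Compound 3 `CCN(CC)CCNc1nc(-c2ccc(NC(=O)Nc3ccccc3F)cc2)nc2ccsc12` has not yet been measured. It differs from compound 1 in a different part of the molecule: diethylamino in place of dimethylamino on a saturated chain carbon, two bonds along the chain from a nitrogen on an aromatic ring. Going by the values given here, no measured step in this set touches that chain, so the one recorded step does not bear on the change directly; it only shows that the far end of the urea can move the number by a modest amount. Lacking any comparable precedent, the step of a 1.2-fold higher number from compound 1 to compound 3 (0.07 log units; within the scatter) is expected to stay within the usual scatter in either direction. Compound 3 is therefore estimated to give 600 nM in this assay, with a plausible range from 250 nM to 1500 nM.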

Compound 3, half-maximal inhibitory concentration: 610 nM
Compound 3: the middle estimate sits 1.0-fold (0.01 log units) below what was measured; measured number inside the range.
By their numbers in this assay, from the lowest: compounds 1 and 3 (each within the scatter of the next); then compound 2.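

For the compounds shown here, the step of a 1.2-fold higher number from compound 1 to compound 3 (0.08 log units; within the scatter) is the first measurement at the far end of the chain, and it shows that in this assay this position accepts diethylamino, with 5 heavy atoms, in place of dimethylamino, with 3, without the two compounds being told apart. The earlier step of a 4.2-fold higher number from compound 1 to compound 2 (0.62 log units; beyond the scatter) concerned only the far end of the urea and lay beyond the scatter, so the series now holds one change that separates compounds and one that does not, though a single change at each place supports no general rule. No measurement available here accounts for this result.

The compounds shown leave open whether the chain end would accept other groups, such as a pyrrolidine or morpholine ring in place of the two ethyl groups, a primary amine, or a longer chain between the two nitrogens. They also leave open whether diethylamino would behave in the same way alongside the 4-methylphenyl group of compound 2, since that pairing of the two changes does not appear among them.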